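From 4-chlorophenyl to 2,4-dichlorophenyl in compound 3

The compounds below may be only part of what the source reports. "The series", "measured", "known", "first", "only" and "open" are said of these compounds alone.

In a functional assay on MGC-803 cells (Homo sapiens) for antiproliferative activity, read by MTT assay, with a stated time of 48 h (a higher number here means that more compound is needed for the effect, a lower number that less compound is needed), compound 1 (`CC1=NN(S(=O)(=O)c2ccccc2)C(c2cc(Br)ccc2O)C1`) gives > 60000 nM, a limit and not a number. Compound 2 (`CC1=NN(S(=O)(=O)c2ccc(Cl)cc2)C(c2cc(Br)ccc2O)C1`) gives > 60000 nM, also a limit. Compound 2 thus stands at the limit of > 60000 nM in this assay, at which 2 of the 2 values shown sit. Compound 3 (`CC1=NN(S(=O)(=O)c2ccc(Cl)cc2Cl)C(c2cc(Br)ccc2O)C1`) carries a further chloro, ortho to a large group: chloro in place of hydrogen on an aromatic carbon. Among the compounds with values here, the one measured step bearing on this is the same kind of change, a step that the two limits leave unreadable from compound 1 to compound 2, so it offers no size to carry over. No clear shift in either direction is expected in this assay. The expected step is an at least 1.2-fold lower number from compound 2 to compound 3 (0.07 log units; that floor lies within the scatter). For compound 3 the estimated value is 50000 nM, with an expected range from 15000 nM to 90000 nM.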

Compound 3, half-maximal effective concentration: 37900 nM
Beside the measured number, compound 3's estimate is 1.3-fold (0.12 log units) above it; measured number inside the range.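

In this assay, within the data shown here, the added chloro, ortho to a large group, gives the first number of the series rather than a limit, with an at least 1.5-fold lower number from compound 2 to compound 3 (0.19 log units; that floor lies within the scatter). The full change on the sulfonyl sulfur, 2,4-dichlorophenyl in place of phenyl, gives an at least 1.5-fold lower number from compound 1 to compound 3 (0.19 log units; that floor lies within the scatter). Both steps are floors only, each starting from a limit: the limit of > 60000 nM in this assay, at which 2 of the 3 values shown sit.

Still open, as far as these compounds go, is whether an amine or a methoxy at this place would give a step beyond the scatter. From the compounds shown here alone, the true size of the chloro step also remains open.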